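Methyl added at the phenyl-bearing ring carbon of compound 2

A few compounds are considered here, and "the series" means these few. Any claim that something is new, unique, unknown or untested is made for them only; others in the source may bear on it.

Compound 1 `FC(F)(F)c1c(CN2CCC(c3ccccc3)CC2)ccn2c(CC3CC3)nnc12` and compound 2 `FC(F)(F)c1c(CN2CCCC(c3ccccc3)C2)ccn2c(CC3CC3)nnc12` share the same core and differ in where the phenyl group sits on the saturated six-membered ring. In an assay on CHO cells for positive allosteric modulation of metabotropic glutamate receptor 2 (Homo sapiens), read by scintillation counting, with a stated time of 30 min (a higher number here means a larger maximal response, a lower number a smaller maximal response), compound 1 gives 261% and compound 2 gives 240%. Compound 2 therefore stands lowest of the two numbers available, with compound 1 the nearer and higher value, a gap beyond the usual scatter. Compound 3 `CC1(c2ccccc2)CCCN(Cc2ccn3c(CC4CC4)nnc3c2C(F)(F)F)C1` has not been measured. It differs from compound 2 by methyl in place of hydrogen on a saturated ring carbon, on a saturated ring carbon two ring bonds from the ring nitrogen, the same carbon that bears the phenyl group. For the measured compounds named here, no pair in this set shows what such an added methyl does, so the expected step of a number 15 percentage points lower from compound 2 to compound 3 (beyond the scatter) is taken as small, most likely within the scatter or a modest drop. Compound 3 is thus estimated at 225%, within a range from 165% to 285%.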

Compound 3, largest response reached (Emax), in percent of the reference or control that the assay uses: 278%
For compound 3 the middle estimate is 53 percentage points below the measured one; the range from low to high includes it.
By their numbers in this assay, from the lowest: compound 2; then compound 1; then compound 3.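

In this assay, for the compounds shown here, methyl in place of hydrogen on the saturated ring carbon that bears the phenyl group gives the first readable single-change step, a number 38 percentage points higher from compound 2 to compound 3 (beyond the scatter), and that step is large. This ring carbon, two ring bonds from the ring nitrogen, therefore accepts an added methyl with a gain in maximal response rather than a loss or no change. No available measurement bears on why the response rises, so the step stands as an observation only.

Whether this gain is specific to methyl remains open, as the compounds shown include no ethyl group, hydroxyl group or fluorine atom on this ring carbon. Also open, on these data alone, is whether an added methyl on the phenyl-bearing ring carbon of compound 1 would produce a similar step.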